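Quinazoline diamines: cytotoxicity step from compound 2 to compound 4

A few compounds are considered here, and "the series" means these few. Any claim that something is new, unique, unknown or untested is made for them only; others in the source may bear on it.

Notes on a small set of furanylmethylamino quinazolines tested for cytotoxicity. The read-out is a functional assay on HCT-116 cells (Homo sapiens) for cytotoxicity, read by MTT assay, with a stated time of 2 days, tested at 10 uM; a lower number here means less inhibition, a higher number more inhibition at the concentration tested (going by the name of the read-out). Compound 1 `CCCCNc1nc(NCc2ccco2)c2ccccc2n1` gives 94.8% in this assay. Compound 3 `CCCCCNc1nc(NCc2ccco2)c2cc(F)ccc2n1`, which carries a pentyl chain and a ring fluorine, gives 94.2% in this assay; the two values lie within the usual scatter of each other. Compound 2 `CN(C)CCNc1nc(NCc2ccco2)c2ccccc2n1`, the analogue with a 2-(dimethylamino)ethyl chain, is reported as "not determined" (no result reported) in this assay, so there is no single number for it to stand on.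

Compound 4 `c1coc(CNc2nc(NCCCN3CCCC3)nc3ccccc23)c1` is the next member. The change from compound 2 to compound 4 is (pyrrolidin-1-yl)methyl in place of dimethylamino on a saturated chain carbon, two bonds along the chain from a nitrogen on an aromatic ring; the same change, cut one bond further out, reads 2-(dimethylamino)ethyl to 3-(pyrrolidin-1-yl)propyl. Among the compounds with values here, no measured pair covers a step of this kind, and compound 2 itself is unmeasured, so the size of the step in this assay cannot be given from data; nothing beyond the scatter is anticipated in either direction. On the strength of compound 1 at 94.8% and compound 3 at 94.2%, compound 4 is expected to give about 82%, in a range from 40% to 99%.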

Compound 4, a percentage reported as inhibition, at one concentration (the size of the read-out at that concentration, not a potency): 67.5%
For compound 4 the middle estimate is 14.5 percentage points above the measured one; the measured number falls inside the stated range.
By their numbers in this assay, from the lowest: compound 4; then compounds 3 and 1 (each within the scatter of the next).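

In this assay, pyrrolidin-1-yl in place of methyl on a saturated chain carbon, three bonds along the chain from a nitrogen on an aromatic ring, gives a number 27.3 percentage points lower from compound 1 to compound 4 (beyond the scatter). Within the data shown here, this position therefore responds to the change, and compound 4 supplies the first step that is beyond the scatter. Nothing available bears on why the number falls.

Among these compounds, the step from compound 2 to compound 4 cannot be read, so the effect of replacing dimethylamino with (pyrrolidin-1-yl)methyl remains unknown, and the single remaining step cannot separate the pyrrolidine ring from the longer chain. On these data alone, how a piperidine, a morpholine or a carboxylic acid on this chain would read also remains open.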